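One added chlorine on the aromatic ring of compound 1

The source may report more compounds than this note shows. Statements on the series, on what has been measured and on what is new or still open speak of the compounds shown alone.

- compound 1 `NC1=NC2(CCSCC2)N(OCCCOc2ccc(Cl)c(Cl)c2)C(N)=N1`: 10 nM
- compound 2 `NC1=NC2(CCOCC2)N(OCCCOc2ccccc2)C(N)=N1`: "not determined" (no result reported)
- compound 3 `NC1=NC2(CCOCC2)N(OCCCOc2ccc(F)cc2)C(N)=N1`: "not determined" (no result reported)

In a functional assay on MDA-MB-231 cells (Homo sapiens) for antiproliferative activity, read by MTT assay, with a stated time of 72 h (a lower number here means a stronger inhibitor, a higher number a weaker inhibitor), compound 1 gives 10 nM. Among the compounds with values here, it is the only compound here with a number, since compound 2 and compound 3 have no reported result. Within the data shown here, compound 1 therefore cannot be ranked against anything, and no measured pair shows how a change in structure moves the result.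

The compound still awaiting measurement is compound 4 `NC1=NC2(CCSCC2)N(OCCCOc2cc(Cl)c(Cl)cc2Cl)C(N)=N1`. It differs from compound 1 at one place on the aromatic ring: chloro in place of hydrogen on an aromatic carbon. In words, chloro replaces hydrogen on an aromatic carbon, ortho to a large group, meta to a chloro group and para to a chloro group. This turns 3,4-dichlorophenyl into 2,4,5-trichlorophenyl, and the rest of the structure stays the same.

Among the measured compounds shown here, with no measured example of this change, the only anchor is compound 1 at 10 nM. No direction can be favoured, so the expectation is for no shift beyond the usual scatter of repeated measurements, although the range must stay wide. The estimated change is no change at the digits printed from compound 1 to compound 4 (within the scatter). For compound 4 the estimated value in this assay is 10 nM, with an expected range of 3 nM to 40 nM.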

Compound 4, half-maximal inhibitory concentration: 110 nM
Compound 4: the middle estimate sits 11-fold (1.04 log units) below what was measured; measured number outside the range, above it.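

In this assay, adding a single chloro ortho to a large group, meta to a chloro group and para to a chloro group gives an 11-fold higher number from compound 1 to compound 4 (1.04 log units; beyond the scatter), a step beyond the usual scatter of repeated measurements. Within the data shown here, this is the first measured pair in the set, and it shows that this place on the aromatic ring is not indifferent to substitution: going from 3,4-dichlorophenyl to 2,4,5-trichlorophenyl gives a weaker inhibitor, even though the change amounts to one heavy atom and the rest of the structure stays the same. No supporting measurement is available to explain this step.

Among these compounds, with only one pair, it remains open whether the weaker result belongs to chloro in particular or would also follow from a smaller or different group at the same place, such as a methyl, a methoxy or an amine. From the compounds shown here alone, it is also open whether the step would keep its size with a longer chain between the oxygen and the aromatic ring, or on a different core.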